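The source may report more compounds than this note shows. Statements on the series, on what has been measured and on what is new or still open speak of the compounds shown alone.

Measured so far:
compound 1, `COc1cc(/C=C/c2ccc(C3=C(c4ccc(O)cc4)C4CC(S(=O)(=O)Oc5ccccc5)C3O4)cc2)cc(OC)c1`: > 100000 nM
compound 2, `O=S(=O)(Oc1ccccc1Cl)C1CC2OC1C(c1ccc(/C=C/c3cc(O)cc(O)c3)cc1)=C2c1ccc(O)cc1`: 40400 nM

In a functional assay on MCF7 cells (Homo sapiens) for antiproliferative activity, read by MTT assay, with a stated time of 72 h (on this read-out higher numbers stand for weaker inhibition and lower numbers for stronger inhibition), compound 1 gives > 100000 nM, which is a limit of the assay rather than a number. In this assay compound 2 gives 40400 nM, the only numerical value among the two shown. Because the value of compound 1 is a limit, compound 2 cannot be ranked against compound 1 beyond what the limit of > 100000 nM in this assay, at which 1 of the 2 values shown sits, states. Going by the values given here, no pair of measured compounds differs in a single place, so no measured step is available.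

Compound 3, `O=S(=O)(Oc1cccc(Cl)c1)C1CC2OC1C(c1ccc(/C=C/c3cc(O)cc(O)c3)cc1)=C2c1ccc(O)cc1`, has not yet been measured in this assay. It differs from compound 2 by 3-chlorophenyl in place of 2-chlorophenyl on an oxygen. The two compounds share every atom and differ only in how the chlorine is joined to the phenoxy ring on the sulfonyl oxygen. Among the compounds with values here, with no measured step to lean on, the step from compound 2 to compound 3 is expected to be small, in either direction, and most likely not beyond the usual scatter: a 1.2-fold lower number from compound 2 to compound 3 (0.06 log units; within the scatter) is the expectation. For compound 3 in this assay the estimate is 35000 nM, with a range from 12000 nM to 100000 nM.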

Compound 3, half-maximal inhibitory concentration: 12900 nM
For compound 3 the middle estimate is 2.7-fold (0.43 log units) above the measured one; the range from low to high includes it.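

In this assay, the position of the chlorine on the phenyl ring carried by the sulfonyl oxygen proves to matter, since 3-chlorophenyl in place of 2-chlorophenyl gives a 3.1-fold lower number from compound 2 to compound 3 (0.50 log units; beyond the scatter). Going by these compounds alone, the two compounds have the same atoms joined differently, so this step isolates the placement of the chlorine alone, which the earlier compounds could not do because no pair of them differed in a single place. Nothing measured here gives a reason for this step.

On these data alone, what remains open is whether the gain belongs to the chlorine specifically or would also appear with a methyl, a nitrile or an amine in its place, and whether the step would hold on a different version of the shared core. Compound 1 differs from both other compounds in more than one place and its reading is a limit of the assay, so any step involving it cannot be read: the limit of > 100000 nM in this assay, at which 1 of the 3 values shown sits.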